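The compounds below may be only part of what the source reports. "The series", "measured", "known", "first", "only" and "open" are said of these compounds alone.

Measured so far in an ADME assay on L6 cells (Rattus norvegicus) for cytotoxicity, read by resazurin assay, with a stated time of 72 h; on this read-out higher numbers stand for weaker inhibition and lower numbers for stronger inhibition:
compound 1 `NC1CC2(N3CCCCC3)CC(c3ccccc3)C1C(c1ccccc1)C2` gives 35000 nM
compound 2 `O=C(CN1CCCCC1)OC1CC2(N3CCCCC3)CC(c3ccccc3)C1C(c1ccccc1)C2` gives 60400 nM
compound 3 `CN(C)C12CC(N)C(C(c3ccccc3)C1)C(c1ccccc1)C2` gives 40900 nM

Compound 4 `CN(C)C12CC(OC(=O)CN3CCCCC3)C(C(c3ccccc3)C1)C(c1ccccc1)C2` is not yet measured. From compound 3 the change is (((piperidin-1-yl)methyl)carbonyl)oxy in place of amino on a saturated ring carbon. The same kind of change is already seen once, from compound 1 to compound 2, as (((piperidin-1-yl)methyl)carbonyl)oxy in place of amino on a saturated ring carbon, where it made a 1.7-fold higher number from compound 1 to compound 2 (0.24 log units; within the scatter). The two cores differ by dimethylamino in place of piperidin-1-yl on a saturated ring carbon, and the step that goes with it, a 1.2-fold higher number from compound 1 to compound 3 (0.07 log units; within the scatter), is small. The surroundings of the place are not identical: for compound 1 the place lies two ring bonds from the ring atom that bears a piperidin-1-yl group, for compound 3 two ring bonds from the ring atom that bears a dimethylamino group, so the change is the same kind, not the same. Going by the values given here, for compound 4 a step of a 1.7-fold higher number from compound 3 to compound 4 (0.23 log units; within the scatter) in this assay is expected, because a 1.7-fold higher number from compound 1 to compound 2 (0.24 log units; within the scatter) is the only precedent. The estimate for compound 4 is 70000 nM. The expected range for compound 4 runs from 35000 nM to 140000 nM.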

Compound 4, half-maximal inhibitory concentration: 29300 nM
The estimate for compound 4 lay 2.4-fold (0.38 log units) above the measured number; measured number below the stated range.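

In this assay, (((piperidin-1-yl)methyl)carbonyl)oxy in place of amino gives a 1.4-fold lower number from compound 3 to compound 4 (0.14 log units; within the scatter), and this step does not differ beyond the scatter from the one on the core of compound 1: the same change on two cores in this assay, a 1.7-fold higher number (0.24 log units; within the scatter) from compound 1 to compound 2 and a 1.4-fold lower number (0.14 log units; within the scatter) from compound 3 to compound 4, 2.4-fold (0.38 log units) apart, within the scatter of two such steps

Dimethylamino in place of piperidin-1-yl gives a 2.1-fold lower number from compound 2 to compound 4 (0.31 log units; beyond the scatter), a modest step that also stays within the scatter of its counterpart on the other core: the same change on two cores in this assay, a 1.2-fold higher number (0.07 log units; within the scatter) from compound 1 to compound 3 and a 2.1-fold lower number (0.31 log units; beyond the scatter) from compound 2 to compound 4, 2.4-fold (0.38 log units) apart, within the scatter of two such steps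

Neither change shows a dependence on the core here, but with one pair per core this does not show that either change carries over reliably, and it gives neither a direction.

The compounds shown leave open whether a different group on that saturated ring carbon, such as a carboxylic acid or a longer chain ending in an amine, would shift the number beyond the scatter. They also leave open what a morpholin-4-yl group would do in place of piperidin-1-yl.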